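Sulfamoyl carbamates: from an anilino to a difluorophenoxy group

The source may report more compounds than this note shows. Statements on the series, on what has been measured and on what is new or still open speak of the compounds shown alone.

Two carbamates of a shared core have been measured in an assay on liver for inhibition of sterol O-acyltransferase 1 (Rattus norvegicus), using microsomes; a higher number here means a weaker inhibitor, a lower number a stronger inhibitor. Compound 1 `CC(C)c1cccc(C(C)C)c1OC(=O)NS(=O)(=O)N(C(C)C)C(C)C` gives 15000 nM in this assay, and compound 2 `CC(C)c1cccc(C(C)C)c1OC(=O)NS(=O)(=O)Nc1ccccc1` gives 38100 nM. Among the measured compounds shown here, the one step between them, a 2.5-fold higher number from compound 1 to compound 2 (0.40 log units; beyond the scatter), leaves compound 2 as the weaker of the two by a margin beyond the scatter, so compound 2 stands at the highest of the two numbers, with compound 1 as its only neighbour.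

Compound 3 `CC(C)c1cccc(C(C)C)c1OC(=O)NS(=O)(=O)Oc1ccc(F)cc1F` differs from compound 2 in one place: 2,4-difluorophenoxy in place of anilino on a sulfonyl sulfur. For the measured compounds named here, no measured pair shows a phenoxy group on this sulfonyl sulfur, so only the step from compound 1 to compound 2 bears on the question, and it shows that exchanging the group on that sulfur moved the number modestly. With nothing to indicate the direction for an aryloxy group, compound 3 is expected to land near compound 2, with a 1.3-fold lower number from compound 2 to compound 3 (0.10 log units; within the scatter) not clearly beyond the scatter. The estimate for compound 3 in this assay is 30000 nM, within a range from 10000 nM to 90000 nM.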

Compound 3, half-maximal inhibitory concentration: > 50000 nM
Compound 3 was reported as a limit; the forecaster's own chance of this, stated with the estimate: 15%; at least 1.6-fold (0.22 log units) between middle value and limit.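

In this assay compound 3 gives > 50000 nM, which is a limit and not a number, and all that can be read from it rests on that limit: the limit of > 50000 nM in this assay, at which 1 of the 3 values shown sits.

Set against the anilino group, the change gives an at least 1.3-fold higher number from compound 2 to compound 3 (0.11 log units; that floor lies within the scatter), and with that floor inside the scatter no order can be drawn between these two compounds on this sulfonyl sulfur. Set against the diisopropylamino group, it gives an at least 3.3-fold higher number from compound 1 to compound 3 (0.52 log units; beyond the scatter), a step beyond the scatter, so with a group joined through oxygen now shown at this position, compound 1 keeps the lowest number of the three, its steps to both others being beyond the scatter.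

On these data alone, how far compound 3 really lies from compound 2 stays open, as does whether the oxygen link or the two fluorines weigh more in the result. Also open, as far as these compounds go, is what an unsubstituted phenoxy group, a methoxy group or a dimethylamino group would give on this sulfonyl sulfur, and whether any of them would bring the number below that of compound 1.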